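Pyridin-2-yl in place of 4-fluorophenyl

The source may hold more compounds than are shown below. What is called first, only, known or untested is meant among the compounds shown, and "the series" means these compounds.

In an ADME assay on microsomes from liver (Mus musculus) for pharmacokinetics (a lower number here means slower removal, a higher number faster removal of the compound), compound 1 `C[C@H](NC(=O)C1CCOCC1)c1ccc(NC(=O)[C@H]2C[C@@H]2c2cccnc2)cc1` gives 25.1 mL.min-1.g-1, compound 2 `C[C@H](NC(=O)[C@@H]1CCCN1C)c1ccc(NC(=O)[C@H]2C[C@@H]2c2cccnc2)cc1` gives 65.4 mL.min-1.g-1 and compound 3 `C[C@H](NC(=O)c1ccc(F)cc1)c1ccc(NC(=O)[C@H]2C[C@@H]2c2cccnc2)cc1` gives 13.7 mL.min-1.g-1. The record shows a 1.8-fold lower number from compound 1 to compound 3 (0.26 log units; within the scatter), but a 4.8-fold lower number from compound 2 to compound 3 (0.68 log units; beyond the scatter), so compound 3 shares the low end of the range with compound 1. Compound 4 `C[C@H](NC(=O)c1ccccn1)c1ccc(NC(=O)[C@H]2C[C@@H]2c2cccnc2)cc1` carries pyridin-2-yl in place of 4-fluorophenyl on a carbonyl carbon. Among the measured compounds shown here, no measured step makes this exchange. The nearest evidence comes from other changes at the same place, which range from the step within the scatter above to a 2.6-fold higher number from compound 1 to compound 2 (0.42 log units; beyond the scatter). The expected change is small, estimated as a 1.2-fold higher number from compound 3 to compound 4 (0.09 log units; within the scatter), and not beyond the scatter. For compound 4 the estimate is 17 mL.min-1.g-1, with an expected range of 8 mL.min-1.g-1 to 34 mL.min-1.g-1.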

Compound 4, intrinsic clearance in microsomes: < 3.42 mL.min-1.g-1
Compound 4 ended at the assay's limit; the forecaster's own chance of this, stated with the estimate: 2%; at least 4.9-fold (0.69 log units) between middle value and limit.
By their numbers in this assay, from the lowest: compounds 3 and 1 (each within the scatter of the next); then compound 2. At a limit, below all of these: compound 4.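

In this assay compound 4 stands at a limit, not at a number: the limit of < 3.42 mL.min-1.g-1 in this assay, at which 1 of the 4 values shown sits. On this carbonyl carbon, pyridin-2-yl in place of 4-fluorophenyl gives an at least 4.0-fold lower number from compound 3 to compound 4 (0.60 log units; beyond the scatter), so an exchange of one aromatic ring for another moves the number further than oxan-4-yl to 4-fluorophenyl did, whose step stayed within the scatter. Pyridin-2-yl also stands clear of oxan-4-yl, with an at least 7.3-fold lower number from compound 1 to compound 4 (0.86 log units; beyond the scatter), and of 1-methylpyrrolidin-2-yl, with an at least 19-fold lower number from compound 2 to compound 4 (1.28 log units; beyond the scatter).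

As far as these compounds go, how far under the limit compound 4 lies stays open. So does what an unsubstituted phenyl or a pyridin-3-yl would give at this place.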